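A few compounds are considered here, and "the series" means these few. Any claim that something is new, unique, unknown or untested is made for them only; others in the source may bear on it.

Measured compounds:
- compound 1 `N[C@H]1CC[C@H](Nc2c(C(=O)Nc3ccccc3)nc(Br)c3cccnc23)CC1`: 1000 nM
- compound 2 `N[C@H]1CC[C@H](Nc2c(C(=O)NC3CCCCC3)nc(Br)c3cccnc23)CC1`: 5200 nM

In a functional assay on HEY cells (Homo sapiens) for cytotoxicity, read by MTT assay, with a stated time of 72 h (on this read-out lower numbers stand for stronger inhibition and higher numbers for weaker inhibition), compound 2 gives 5200 nM, the higher of the two numbers in hand. Where compound 2 carries cyclohexyl on the amide-type nitrogen, compound 1 carries phenyl, and in this assay compound 1 gives 1000 nM; the step was a 5.2-fold higher number from compound 1 to compound 2 (0.72 log units; beyond the scatter).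

Compound 3 `C[C@H](NC(=O)c1nc(Br)c2cccnc2c1N[C@H]1CC[C@H](N)CC1)c1ccc(F)cc1` is not yet measured in this assay. It differs from compound 2 as follows: 1-(4-fluorophenyl)ethyl in place of cyclohexyl on an amide-type nitrogen. For the measured compounds named here, the only step that bears on it is the one from compound 1 to compound 2, where the non-aromatic ring of carbon only replaced the aromatic one on the same nitrogen and the number rose. Going by the values given here, compound 3 brings an aromatic ring back to that position, carried on a short chain with a defined stereocentre and bearing fluorine, for which no step exists in the set. As far as these compounds go, the expectation is therefore a move back down, of roughly the size seen from compound 1 to compound 2, but with wider uncertainty because the chain and the fluorine are untested. Compound 3 is expected to give about 1500 nM in this assay, in the range 500 nM to 5000 nM, that is a step of a 3.5-fold lower number from compound 2 to compound 3 (0.54 log units; beyond the scatter).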

Compound 3, half-maximal inhibitory concentration: > 10000 nM
Compound 3 ended at the assay's limit (the forecaster's own chance of this, stated with the estimate: 5%); middle value at least 6.6-fold (0.82 log units) away from the limit.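

In this assay compound 3 stands at a limit of the assay, not at a number: the limit of > 10000 nM in this assay, at which 1 of the 3 values shown sits.

An aromatic ring on the amide-type nitrogen does not by itself go with the lower number of compound 1, since with 1-(4-fluorophenyl)ethyl in place of phenyl the result is an at least 10-fold higher number from compound 1 to compound 3 (1.00 log units; beyond the scatter). Against cyclohexyl the result is an at least 1.9-fold higher number from compound 2 to compound 3 (0.28 log units; that floor lies within the scatter), so 1-(4-fluorophenyl)ethyl shows no gain over cyclohexyl at this position, though the size of this step remains unknown and its floor does not separate the two compounds firmly.

The compounds shown do not separate the contributions of the fluorine, the methyl branch and the stereocentre: benzyl, 1-phenylethyl, the opposite enantiomer of 1-(4-fluorophenyl)ethyl and 4-fluorophenyl on the same nitrogen would each bear on one of these. Also open, as far as these compounds go, is whether anything other than a plain phenyl on this nitrogen, such as a phenyl ring carrying an amine or a carboxylic acid, can bring the number below that of compound 1.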